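From ethoxy to trifluoromethoxy on the shared core

The source may hold more compounds than are shown below. What is called first, only, known or untested is meant among the compounds shown, and "the series" means these compounds.

Compound 1 `Cc1ccc2nc(C(=O)Nc3c(F)cc(-c4cccc(F)c4)cc3F)c(C)c(O)c2c1`: > 100000 nM, a limit
Compound 2 `CCc1ccc2nc(C(=O)Nc3c(F)cc(-c4cccc(F)c4)cc3F)c(C)c(O)c2c1`: 15800 nM
Compound 3 `CCOc1ccc2nc(C(=O)Nc3c(F)cc(-c4cccc(F)c4)cc3F)c(C)c(O)c2c1`: > 100000 nM, a limit
Compound 4 `Cc1c(C(=O)Nc2c(F)cc(-c3cccc(F)c3)cc2F)nc2ccc(OC(F)(F)F)cc2c1O`: not yet measured

All four belong to a functional assay on Hep 3B2 cells (Homo sapiens) for antiproliferative activity, read by MTT assay, with a stated time of 24 h; on this read-out lower numbers stand for stronger inhibition and higher numbers for weaker inhibition. Compound 3 stands at > 100000 nM, which is a limit and not a number, the same as the limit of > 100000 nM in this assay, at which 2 of the 3 values shown sit. The change to compound 4 is trifluoromethyl in place of ethyl on an oxygen on an aromatic ring. Among the measured compounds shown here, no measured step makes this change. The closest are an at least 6.3-fold higher number from compound 2 to compound 3 (0.80 log units; beyond the scatter) and an at least 6.3-fold lower number from compound 1 to compound 2 (0.80 log units; beyond the scatter), both beyond the scatter, while a step that the two limits leave unreadable from compound 1 to compound 3 tells nothing. Only compound 2 gives a number, 15800 nM. So at most a modest fall from the limit is expected. The estimated step is an at least 1.6-fold lower number from compound 3 to compound 4 (0.22 log units; that floor lies within the scatter). The expected value for compound 4 is 60000 nM, with an estimated range of 15000 nM to 100000 nM.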

Compound 4, half-maximal inhibitory concentration: 85500 nM
Compound 4: the middle estimate sits 1.4-fold (0.15 log units) below what was measured, and the stated range covers the measured number.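

Trifluoromethoxy gives the first number rather than a limit for a group joined through oxygen at this position, yet with an at least 1.1-fold lower number from compound 3 to compound 4 (0.06 log units; that floor lies within the scatter) and an at least 1.1-fold lower number from compound 1 to compound 4 (0.06 log units; that floor lies within the scatter), neither step shows a gain beyond the scatter. Ethyl keeps its lead over trifluoromethoxy, with a 5.4-fold higher number from compound 2 to compound 4 (0.73 log units; beyond the scatter). Compound 1 and compound 3 each hold only a limit: the limit of > 100000 nM in this assay, at which 2 of the 4 values shown sit.

On these data alone, how far compound 3 truly lies from compound 4 stays open. So does whether an amine or a longer carbon chain at this position would match ethyl.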